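The source may report more compounds than this note shows. Statements on the series, on what has been measured and on what is new or still open speak of the compounds shown alone.

Compound 1 `COc1ccc(-c2nc(N=C(N)N)sc2-c2ccc(OC)cc2)cc1`: 2 uM in a functional assay (aorta) with Rattus norvegicus as the target; on this read-out higher numbers stand for an effect only at larger amounts of compound and lower numbers for an effect already at smaller amounts
Compound 2 `COc1ccc(-c2nc(/N=C(\N)N3CCOCC3)sc2-c2ccc(OC)cc2)cc1`: 66 uM
Compound 3 `COc1ccc(-c2nc(CNC(=O)CSc3ccccc3)sc2-c2ccc(OC)cc2)cc1`: 4.2 uM

Compound 2 stands at the highest number of the three in this assay, beyond the scatter from both compound 3 and compound 1. Compound 4 `COc1ccc(-c2nc(C(=O)N(C)C)sc2-c2ccc(OC)cc2)cc1` differs from compound 2 as follows: a group of 5 heavy atoms (3 carbon, 1 nitrogen, 1 oxygen; no ring) in place of a group of 9 heavy atoms (5 carbon, 3 nitrogen, 1 oxygen; one six-membered non-aromatic ring with 2 hetero atoms), on an aromatic carbon. For the measured compounds named here, the only measured step that touches this position is a 33-fold higher number from compound 1 to compound 2 (1.52 log units; beyond the scatter), which shows that what sits here moves the number a great deal. Compound 3 shows that a substituent without a guanidine can still give 4.2 uM. Going by the values given here, no measured step connects the group of compound 2 to a dimethylcarbamoyl, so the direction is uncertain. Compound 4 is therefore expected to fall at about 20 uM, within 4 uM to 100 uM, a step of a 3.3-fold lower number from compound 2 to compound 4 (0.52 log units; beyond the scatter) being expected.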

Compound 4, concentration for half-maximal effect: 3 uM
Estimate against measurement, compound 4: 6.7-fold (0.82 log units) above, outside the stated range (below it).
By their numbers in this assay, from the lowest: compounds 1, 4 and 3 (each within the scatter of the next, the first and the last beyond it); then compound 2.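

In this assay, the dimethylcarbamoyl group on this aromatic carbon gives a 22-fold lower number from compound 2 to compound 4 (1.34 log units; beyond the scatter), so the large number is tied to the group that leaves rather than to every replacement of the guanidine. The other comparison, a 1.5-fold higher number from compound 1 to compound 4 (0.18 log units; within the scatter), shows that a group with no guanidine and no hydrogen-bond donor can read alike with the guanidine here. Nothing measured explains why these groups differ.

The compounds shown leave open whether a simple amine or a carboxylic acid in this place would give a low number or a high one.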